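Adding an Aminoamino Group to Compound 3

The source may report more compounds than this note shows. Statements on the series, on what has been measured and on what is new or still open speak of the compounds shown alone.

Of the compounds shown here, three have so far been tested in a functional assay on the whole organism for inhibition, with Rattus norvegicus as the target, with stated times of 1 h and 3.5 h, at a dose of 100 mg/kg by the oral route; a higher number here means more inhibition at the dose given (going by the name of the read-out), a lower number less inhibition. Compound 1 `CC(=O)Nc1nccc(-c2ccncc2)n1` gives 52% in this assay. Compound 2 `CC(C)(C)C1CCc2nc(N)ncc2C1` gives 41% in this assay. Compound 3 `CC(C)(C)c1ncncc1-c1ccccc1` gives 48% in this assay. Among these three numbers compound 3 stands second highest, yet its nearest neighbour, compound 1, lies within the usual scatter of it, and so does the furthest, compound 2; none of the three can be set apart from the others on the numbers alone. Within the data shown here, no pair of the measured compounds differs in a single place, so no measured step is available to guide the next prediction.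

Compound 4 `CC(C)(C)c1nc(NN)ncc1-c1ccccc1` has not yet been measured. It differs from compound 3 by aminoamino in place of hydrogen on an aromatic carbon. The entering group sits on an aromatic carbon of a six-membered aromatic ring with 2 nitrogen, between two ring nitrogen atoms, meta to a tert-butyl group and para to a phenyl group.

Among the measured compounds shown here, with no comparable step on record, the step of no change at the digits printed from compound 3 to compound 4 (within the scatter) is expected to be none beyond the scatter. Compound 4 is therefore estimated to give 48% in this assay, with an expected range of 28% to 68%.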

Compound 4, a percentage reported as inhibition, in the whole organism at one dose (the size of the read-out at that dose, not a potency): < 5%
Compound 4 gave a limit, no number; the forecaster's own chance of this, stated with the estimate: 2%; middle value at least 43 percentage points from the limit.
By their numbers in this assay, from the lowest: compounds 2, 3 and 1 (each within the scatter of the next, the first and the last beyond it). At a limit, below all of these: compound 4.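

The position between two ring nitrogen atoms, meta to a tert-butyl group and para to a phenyl group, proves far from indifferent in this assay: aminoamino in place of hydrogen on an aromatic carbon at this place gives a number at least 43 percentage points lower from compound 3 to compound 4 (beyond the scatter). Among these compounds, this is the first single-place step available, and it shows that a small group of two nitrogen atoms on the shared core can remove nearly all of the inhibition seen at the dose given. Compound 4 stands at a limit and not at a number, so the step has only a lower bound on its size: the limit of < 5% in this assay, at which 1 of the 4 values shown sits.

The compounds shown leave open whether this drop belongs to aminoamino in particular or would follow from any group at this place, a question that a plain amine or a methyl group on the core of compound 3 would address. They also leave open whether aminoamino would have a similar effect on the core of compound 1 or the core of compound 2.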